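The compounds below may be only part of what the source reports. "The series", "measured", "known", "first", "only" and "open" are said of these compounds alone.

Compound 2 `O=C(NCc1ccncc1)Nc1ccc(S(=O)(=O)N2CC3CCC(C2)O3)cc1` and compound 1 `CCOC(=O)c1ccc(NC(=O)NCc2c[nH]nn2)cc1` share a urea core that joins a substituted aniline to a methylene-linked heterocycle, and both were tested in an assay on isolated protein for activation of Nicotinamide phosphoribosyltransferase (Homo sapiens); on this read-out lower numbers stand for an effect already at smaller amounts and higher numbers for an effect only at larger amounts of compound. Of the two numerical results, compound 2 has the lower number, giving 279 nM, while compound 1 gives 7750 nM. Compound 3 `CCOC(=O)c1ccc(NC(=O)N(C)Cc2ccncc2)cc1` carries a methyl group on the urea nitrogen that bears the pyridylmethyl arm. In this assay compound 3 gives > 100000 nM; this is not a number but a limit of the assay, and compound 3 sits at the limit of > 100000 nM in this assay, at which 1 of the 3 values shown sits.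

Compound 4 `O=C(NCc1ccncc1)Nc1ccc(S(=O)(=O)c2cccc(Cl)c2)cc1` has not yet been measured. It differs from compound 2 in one place (a group of 7 heavy atoms (6 carbon, 1 chlorine; one six-membered aromatic ring of carbon only) in place of a group of 8 heavy atoms (6 carbon, 1 nitrogen, 1 oxygen; one five-membered non-aromatic ring with 1 hetero atom, one six-membered non-aromatic ring with 2 hetero atoms), on a sulfonyl sulfur). The pyridylmethyl urea of compound 2 is kept unchanged, and only the group on the sulfonyl sulfur is exchanged.

Among the measured compounds shown here, since no step between two measured compounds isolates a change of this kind, the expected size of the step from compound 2 to compound 4 rests on the structural change alone; a modest shift, likely within the scatter or slightly favourable, is estimated as a 1.9-fold lower number from compound 2 to compound 4 (0.27 log units; within the scatter). Compound 4 is therefore expected to give about 150 nM in this assay, with a likely range from 40 nM to 600 nM.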

Compound 4, half-maximal effective concentration: 69 nM
For compound 4 the middle estimate is 2.2-fold (0.34 log units) above the measured one; measured number inside the range.
By their numbers in this assay, from the lowest: compound 4; then compound 2; then compound 1. At a limit, above all of these: compound 3.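

In this assay, the group on the sulfonyl sulfur proves to be a place where a single exchange counts: with the pyridylmethyl urea kept unchanged, putting 3-chlorophenyl in place of the non-aromatic two-ring group brings a 4.0-fold lower number from compound 2 to compound 4 (0.61 log units; beyond the scatter). This is the first step among the compounds shown that changes one place only, and it shows that this position accepts an aromatic ring of carbon only, with no hydrogen-bond acceptor in the group, and still gives a lower number. No measurement shown accounts for the size of this step.

From the compounds shown here alone, the exchange alters the ring type, the chlorine and the acceptor count all at once, so their separate contributions stay unknown. An unsubstituted phenyl, a 4-chlorophenyl or a simple piperidine on the same sulfonyl sulfur would be needed to tell them apart.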